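Furan-to-substituted-benzyl swap on the amine-borne chain

The source may hold more compounds than are shown below. What is called first, only, known or untested is meant among the compounds shown, and "the series" means these compounds.

Working notes on the series. In a physicochemical assay for acid dissociation, compound 3 `Fc1ccc(Cc2ccc3c(NCCCNCc4ccco4)ccnc3c2)c(Cl)c1` gives 9.47; it stands level with compound 1 `COc1cccc(CNCCCNc2ccnc3cc(-c4ccc(F)cc4)ccc23)c1O`, which gives 9.47, and with compound 2 `COc1cccc(CNCCCNc2ccnc3cc(-c4ccc(C(C)(C)C)cc4)ccc23)c1O`, which gives 9.47. Among the measured compounds shown here, the only measured step, no change at the digits printed from compound 1 to compound 2 (within the scatter), so a change on the aryl substituent at the far end of the core left the read-out where it was. Compound 4 `COc1cccc(CNCCCNc2ccnc3cc(Cc4ccc(F)cc4Cl)ccc23)c1O` differs from compound 3 in one place: 2-hydroxy-3-methoxyphenyl in place of furan-2-yl on a saturated chain carbon bound to an amine nitrogen. For the measured compounds named here, no measured step covers this exact swap, but compounds 1 and 2 already carry the entering 2-hydroxy-3-methoxybenzyl group on the same chain and show the same value as compound 3 with its (furan-2-yl)methyl group, so the bearing evidence points to no step beyond the scatter. The step from compound 3 to compound 4 is therefore expected to be no change at the digits printed from compound 3 to compound 4 (within the scatter). Compound 4 is expected to give 9.47 in this assay, estimated within 9.1 to 9.8.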

Compound 4, acid dissociation constant: 9.47
The estimate for compound 4 equals the measured number at the digits printed; low and high end bracket the measured number.
By their numbers in this assay, from the lowest: compounds 1, 2, 3 and 4 (each within the scatter of the next).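

In this assay, among the compounds shown here, putting 2-hydroxy-3-methoxyphenyl in place of furan-2-yl on a saturated chain carbon bound to an amine nitrogen gives no change at the digits printed from compound 3 to compound 4 (within the scatter), a direct reading of a swap that the earlier compounds bore on only indirectly. On the aromatic carbon, 2-chloro-4-fluorobenzyl in place of 4-(tert-butyl)phenyl gives no change at the digits printed from compound 2 to compound 4 (within the scatter), and in place of 4-fluorophenyl it gives no change at the digits printed from compound 1 to compound 4 (within the scatter), so neither exchange moves the read-out beyond the scatter. No supporting measurement is available to account for these readings.

With all steps within the scatter, the compounds shown do not tell which part of the structure, if any, sets this read-out. Open, going by these compounds, is whether a carboxylic acid at the place of the 2-hydroxy-3-methoxyphenyl, or a longer chain bearing the amine nitrogen, would shift the number.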